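The source may report more compounds than this note shows. Statements on the series, on what has been measured and on what is new or still open speak of the compounds shown alone.

Compound 1 `COc1cc(Cl)cc(-c2nn(-c3cccc(NC(=O)Nc4ccc(Cl)c(C(F)(F)F)c4)c3)cc2-c2ccncc2)c1` gives -16.8% in a functional assay on MDA-MB-435 cells (Homo sapiens) for inhibition, read by sulforhodamine B assay, with a stated time of 48 h, tested at 10 uM; a lower number here means a stronger effect, a higher number a weaker effect of the compound at the concentration tested.
Compound 2 `COc1cc(Cl)cc(-c2nn(-c3cccc(NC(=O)c4cccc(C(F)(F)F)c4)c3)cc2-c2ccncc2)c1` gives 65.6% in this assay.
Compound 3 `O=C(Nc1cccc(-n2cc(-c3ccncc3)c(-c3cc(O)cc(Cl)c3)n2)c1)c1cc(C(F)(F)F)cc(C(F)(F)F)c1` gives 45.6% in this assay.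

Compound 3 stands second highest of the three numbers: beyond the scatter above compound 2, and far above compound 1, which is the lowest of the set. Compound 4 `COc1cc(Cl)cc(-c2nn(-c3cccc(NC(=O)c4cc(C(F)(F)F)cc(C(F)(F)F)c4)c3)cc2-c2ccncc2)c1` differs from compound 3 by methyl in place of hydrogen on an oxygen on an aromatic ring. Going by the values given here, the only measured step, a number 82.4 percentage points higher from compound 1 to compound 2 (beyond the scatter), concerns the amide side of the molecule and does not bear on this exchange; no measured pair shows the hydroxy to methoxy change alone. Compound 2 carries the methoxy but a different benzamide, so its value set against compound 3 mixes two changes. The step of a number 4.4 percentage points higher from compound 3 to compound 4 (within the scatter) is therefore expected to be none beyond the scatter. Compound 4 is estimated at 50%, between 20% and 80%.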

Compound 4, a percentage reported as activity, at one concentration (the size of the read-out at that concentration, not a potency): 80%
For compound 4 the middle estimate is 30 percentage points below the measured one, within the range that was stated.
By their numbers in this assay, from the lowest: compound 1; then compound 3; then compound 2; then compound 4.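

In this assay, going by these compounds alone, methyl in place of hydrogen on the oxygen, hydroxy to methoxy, gives a number 34.4 percentage points higher from compound 3 to compound 4 (beyond the scatter), the first reading of this change alone, and the hydroxy form has the stronger effect at the concentration tested. With the methoxy held constant, trifluoromethyl in place of hydrogen on an aromatic carbon gives a number 14.4 percentage points higher from compound 2 to compound 4 (beyond the scatter), so this second place also moves the read-out. Nothing available explains either step. As far as these compounds go, whether an ethoxy group or an amine in place of the hydroxy would stay near the value of compound 3 remains open. So does whether the hydroxy to methoxy change gives a similar step with the amide side of compound 1.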